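Methoxy for Fluoro on the Phenyl Ring of Compound 1

The compounds below may be only part of what the source reports. "The series", "measured", "known", "first", "only" and "open" are said of these compounds alone.

Measured compounds:
compound 1, `Cn1c(-c2ccccc2F)cnc1NC(=O)c1ccc(F)cc1`: > 100000 nM
compound 2, `O=C(Nc1ncc(-c2ccccc2)o1)c1ccc(Cl)cc1`: 10000 nM

The study looked at two amides in a toxicity assay on THP-1 cells (Homo sapiens) for inhibition; a lower number here means that less compound is tolerated, a higher number that more compound is tolerated. Compound 1 gives > 100000 nM, which is a limit of the assay and not a number. Compound 2, built on a different core, gives 10000 nM in this assay. Where compound 1 stands on the numbers is therefore known only in part, because the limit of > 100000 nM in this assay, at which 1 of the 2 values shown sits, is all that is recorded for it.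

Compound 3, `COc1ccccc1-c1cnc(NC(=O)c2ccc(F)cc2)n1C`, has not yet been measured. It differs from compound 1 in a single place: methoxy in place of fluoro on an aromatic carbon. Among the compounds with values here, no pair of measured compounds differs in only one spot, so no measured step sets the size of such a change. Compound 3 is expected to stay near compound 1, with a step of a number no higher from compound 1 to compound 3 (the limit leaves the size open) that is not expected to exceed the scatter of this assay. The estimate for compound 3 is 100000 nM, between 30000 nM and 300000 nM, with a good chance that this assay again returns only a limit.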

Compound 3, half-maximal cytotoxic concentration: > 100000 nM
Compound 3 gave a limit, no number; the forecaster's own chance of this, stated with the estimate: 55%; the middle value sits exactly at the limit.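

In this assay compound 3 returns a limit and no number, as compound 1 does, so no step can be read between these two compounds: the limit of > 100000 nM in this assay, at which 2 of the 3 values shown sit. The compounds shown leave open how far methoxy in place of fluoro on an aromatic carbon moves this read-out, and at what concentration, if any, compound 1 or compound 3 becomes cytotoxic.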